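A few compounds are considered here, and "the series" means these few. Any claim that something is new, unique, unknown or untested is made for them only; others in the source may bear on it.

Within the data shown here, in a physicochemical assay for solubility, read by turbidimetry, measured as kinetic solubility, at pH 6.8 (on this read-out higher numbers stand for higher solubility and lower numbers for lower solubility), compound 1 (`CC1SC(c2cccc(C(=O)NCCCCc3ccccc3)c2)N(c2ccc(C3CC3)cc2)C1=O`) gives 10000 nM and holds the higher of the two numbers known so far. Compound 2 (`O=C(NCCCCc1ccccc1)c1cccc(C2SCC(=O)N2c2ccc(C3CC3)cc2)c1`) gives 2000 nM on the same read-out. Compound 3 (`COc1ccccc1N1C(=O)C(C)SC1c1cccc(C(=O)NCCCCc2ccccc2)c1`) has not yet been measured. It keeps the core of compound 1, methyl group included, and differs by 2-methoxyphenyl in place of 4-cyclopropylphenyl on an amide-type nitrogen in a ring. The count 2-methoxyphenyl in place of 4-cyclopropylphenyl on an amide-type nitrogen in a ring sets out what leaves and what enters at that place.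

Among the measured compounds shown here, the only measured step of a 5.0-fold lower number from compound 1 to compound 2 (0.70 log units; beyond the scatter) is modest and lies beyond the scatter. For the measured compounds named here, that step is hydrogen in place of methyl on a saturated ring carbon, so it serves only as a guide to size, and no measured step touches the group on the nitrogen. A modest step of similar size is therefore expected in this assay and a higher number is judged somewhat more likely, though the data do not settle the direction. The estimated step is a 1.5-fold higher number from compound 1 to compound 3 (0.18 log units; within the scatter) at the middle of the expectation. For compound 3 the estimated value is 15000 nM with an expected range from 4000 nM to 50000 nM in this measurement.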

Compound 3, solubility: 20000 nM
The estimate for compound 3 lay 1.3-fold (0.12 log units) below the measured number, and the stated range covers the measured number.
By their numbers in this assay, from the lowest: compound 2; then compounds 1 and 3 (each within the scatter of the next).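

In this assay, among these compounds, the first read on the group on the amide-type nitrogen in a ring comes from 2-methoxyphenyl in place of 4-cyclopropylphenyl, with the core of compound 1 and its methyl group kept: a 2.0-fold higher number from compound 1 to compound 3 (0.30 log units; within the scatter). Although the group that leaves carries a three-membered ring and the group that enters carries an oxygen, this exchange does not separate the two compounds on this read-out, and the only step shown beyond the scatter remains the one at the ring atom that bears a methyl group, a 5.0-fold lower number from compound 1 to compound 2 (0.70 log units; beyond the scatter). Nothing in hand accounts for either step, so the result stands as an observation only.

It remains open whether removing that methyl group would give a step of similar size with 2-methoxyphenyl on the nitrogen, since the one such step shown has 4-cyclopropylphenyl there. Among the compounds shown here, also open is how the read-out would respond to a phenyl ring carrying an amine or a carboxylic acid at this place, as only two neutral groups have been compared here.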